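This account rests on a few compounds, and the source may have more. Where it says the series, first, only, none or still open, it means among the compounds named here.

Compound 1 `Cc1nc(N)c2c(-c3ccccc3)cn([C@@H]3O[C@H](CO)[C@@H](O)[C@H]3O)c2n1` and compound 3 `CNc1ncnc2c1c(-c1ccccc1)cn2[C@@H]1O[C@H](CO)[C@@H](O)[C@H]1O` are built from the same atoms joined differently; the difference between their two cores is not broken down here. In an ADME assay on MRC5 cells (Homo sapiens), read by MTT assay, with a stated time of 72 h (a higher number here means a weaker inhibitor, a lower number a stronger inhibitor), compound 1 reaches only a limit of the assay, > 100000 nM. Compound 2 `Cc1nc(N)c2c(-c3cccs3)cn([C@@H]3O[C@H](CO)[C@@H](O)[C@H]3O)c2n1` carries the change (thiophen-2-yl in place of phenyl on an aromatic carbon). In this assay compound 2 likewise gives a limit, > 100000 nM. The step from one to the other is a step that the two limits leave unreadable from compound 1 to compound 2. Compound 3, in this assay, also gives a limit, > 100000 nM. Among the compounds with values here, compound 4 `CNc1ncnc2c1c(-c1cccs1)cn2[C@@H]1O[C@H](CO)[C@@H](O)[C@H]1O` has not been measured; it differs from compound 3 by thiophen-2-yl in place of phenyl on an aromatic carbon, the same change as the one between compound 1 and compound 2. Within the data shown here, every value so far sits at the limit of > 100000 nM in this assay, at which 3 of the 3 values shown sit. Because the limit of > 100000 nM in this assay, at which 3 of the 3 values shown sit, holds for all three compounds, compound 4 is expected to stay at that limit too, and the step that the limit leaves unreadable from compound 3 to compound 4 is expected to be essentially flat. For compound 4 the estimate in this assay is 150000 nM, between 100000 nM and 300000 nM, most probably reported as a limit rather than a number.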

Compound 4, half-maximal inhibitory concentration: > 100000 nM
Compound 4 was reported as a limit (the forecaster's own chance of this, stated with the estimate: 90%); the middle value lies beyond the limit too.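

In this assay, compound 3 and compound 4 both give only a limit, and the step between them, thiophen-2-yl in place of phenyl, cannot be read. All the compounds shown share one limit: the limit of > 100000 nM in this assay, at which 4 of the 4 values shown sit. The compounds shown leave open how far beyond that limit each one lies, and whether this change alters the value at all.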